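Aryl substituent change in a hydroxamate series

The compounds below may be only part of what the source reports. "The series", "measured", "known", "first", "only" and "open" are said of these compounds alone.

Measured compounds:
compound 1 `CCOc1ccc(CCCN2CC=C(CCC(=O)NO)C2=O)cc1` — 3330 nM
compound 2 `Cc1ccc(CCCN2CC=C(CCC(=O)NO)C2=O)cc1` — 3330 nM

In a functional assay on ACHN cells (Homo sapiens) for inhibition, read by sulforhodamine B assay (a higher number here means a weaker inhibitor of growth, a lower number a stronger inhibitor of growth), compound 1 gives 3330 nM. Compound 2 gives 3330 nM in this assay. Among the measured compounds shown here, the one measured step, no change at the digits printed from compound 1 to compound 2 (within the scatter), exchanges one group on the aromatic carbon for another and moves the read-out not at all beyond the usual scatter. Compound 2 therefore stands level with compound 1 on these numbers, and nothing in the pair separates the two.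

Compound 3 `CC(C)c1ccc(CCCN2CC=C(CCC(=O)NO)C2=O)cc1` is the next member. Its change from compound 2 is isopropyl in place of methyl on an aromatic carbon. The step that bears on it is no change at the digits printed from compound 1 to compound 2 (within the scatter), since it also alters only the group on that aromatic carbon, and it was flat. For the measured compounds named here, with no measured step at this position showing any shift, the expectation for compound 3 is a step of a 1.1-fold lower number from compound 2 to compound 3 (0.05 log units; within the scatter), that is, none beyond the scatter in this assay. Compound 3 is accordingly estimated at 3000 nM, with a range from 1200 nM to 7500 nM.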

Compound 3, concentration for 50% growth inhibition: 3330 nM
Compound 3: the middle estimate sits 1.1-fold (0.05 log units) below what was measured; the measured number falls inside the stated range.
By their numbers in this assay, from the lowest: compounds 1, 2 and 3 (each within the scatter of the next).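

In this assay, the read-out shows no change at the digits printed from compound 2 to compound 3 (within the scatter) when isopropyl, 3 heavy atoms, replaces methyl, 1 heavy atom, on an aromatic carbon para to a large group, so a difference in carbon count at this position now stands beside the earlier exchange of ethoxy for methyl. Exchanging ethoxy for isopropyl gives no change at the digits printed from compound 1 to compound 3 (within the scatter), which places ethoxy, methyl and isopropyl level at this position, with and without an ether oxygen in the group. The data at hand offer no explanation for this flat read-out.

The compounds shown leave open whether a charged group such as a carboxylic acid or an amine, or a group such as trifluoromethyl, would also stay level at this position, as all three groups here carry no net charge and have no hydrogen-bond donors or acceptors counted under the change from methyl to isopropyl. They also leave open whether a longer chain elsewhere on the shared core, which stays the same across all three compounds, would shift the read-out.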